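Trifluoromethyl on the benzyl ring of a vinyl sulfone catechol

A few compounds are considered here, and "the series" means these few. Any claim that something is new, unique, unknown or untested is made for them only; others in the source may bear on it.

Working notes on the series. Compound 1 `O=S(=O)(/C=C/c1ccc(O)c(O)c1)Cc1ccccc1` and compound 2 `O=S(=O)(/C=C/c1ccc(O)c(O)c1)CCCCc1ccccc1` share a core and differ only in the chain that joins the sulfone to the terminal phenyl ring. In a functional assay on BV-2 cells (Mus musculus) for inhibition, read by Griess assay, with stated times of 3 h and 24 h (on this read-out lower numbers stand for stronger inhibition and higher numbers for weaker inhibition), compound 1 gives 11600 nM, and compound 2 gives 19800 nM. Among the compounds with values here, compound 1 has the lowest of the two numbers measured so far, but its nearest neighbour, compound 2, lies within the scatter of it, so no order between the two can be read. Within the data shown here, no step between measured compounds speaks to a substituent on the terminal phenyl ring.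

Compound 3 `O=S(=O)(/C=C/c1ccc(O)c(O)c1)Cc1ccc(C(F)(F)F)cc1` is derived from compound 1 by trifluoromethyl in place of hydrogen on an aromatic carbon. With nothing measured on that ring, the expectation rests on compound 1 alone. The step of a 1.0-fold higher number from compound 1 to compound 3 (0.01 log units; within the scatter) in this assay is expected to be small, in neither direction beyond the scatter. For compound 3 the estimate in this assay is 12000 nM, with a range from 4000 nM to 36000 nM.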

Compound 3, half-maximal inhibitory concentration: 15900 nM
Compound 3: middle estimate off by 1.3-fold (0.12 log units), on the low side; measured number inside the range.
By their numbers in this assay, from the lowest: compounds 1, 3 and 2 (each within the scatter of the next).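

In this assay trifluoromethyl in place of hydrogen on an aromatic carbon, para to a large group, gives a 1.4-fold higher number from compound 1 to compound 3 (0.14 log units; within the scatter) so this position of the terminal ring takes a group of 4 heavy atoms with no readable change in the number. The series therefore stays unresolved: compound 1, compound 3 and compound 2 each lie within the scatter of the next, and the new substituent adds no order among them. No measurement shown here bears on the reason for the size of this step.

On these data alone, whether an amine or a carboxylic acid on the same aromatic carbon would move the number beyond the scatter remains open. Also open, as far as these compounds go, is whether trifluoromethyl would behave the same way on the terminal ring of compound 2, with its longer chain.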